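Swapping 4-hydroxyphenyl for 2,6-dimethoxyphenyl in a growth-inhibition series

The compounds below may be only part of what the source reports. "The series", "measured", "known", "first", "only" and "open" are said of these compounds alone.

In a functional assay on HCT-116 cells (Homo sapiens) for inhibition, read by sulforhodamine B assay, with a stated time of 48 h (a higher number here means a weaker inhibitor of growth, a lower number a stronger inhibitor of growth), compound 3 `O=C(Cc1csc2nc(-c3ccc(Br)cc3)cn12)N/N=C/c1ccc(O)cc1` gives 10500 nM, within the scatter of compound 1 `O=C(Cc1csc2nc(-c3ccc(Br)cc3)cn12)N/N=C/c1ccccc1` at 9330 nM, whereas compound 2 `O=C(Cc1csc2nc(-c3ccc(Br)cc3)cn12)N/N=C/c1ccccc1O` gives 3240 nM. Hydroxy in place of hydrogen made no real difference in a 1.1-fold higher number from compound 1 to compound 3 (0.05 log units; within the scatter), but a modest one in a 2.9-fold lower number from compound 1 to compound 2 (0.46 log units; beyond the scatter). The two hydroxy compounds stand apart by a 3.2-fold higher number from compound 2 to compound 3 (0.51 log units; beyond the scatter). Compound 4 `COc1cccc(OC)c1/C=N/NC(=O)Cc1csc2nc(-c3ccc(Br)cc3)cn12` brings 2,6-dimethoxyphenyl in place of 4-hydroxyphenyl on a carbon with a double bond to nitrogen. Going by the values given here, no measured step tests methoxy groups, so these modest steps only bound the expectation. The estimated change is small, a 1.8-fold lower number from compound 3 to compound 4 (0.24 log units; within the scatter), and no step beyond the scatter is expected. For compound 4 the estimated value is 6000 nM, with an expected range of 2000 nM to 18000 nM.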

Compound 4, concentration for 50% growth inhibition: 4570 nM
Estimate against measurement, compound 4: 1.3-fold (0.12 log units) above; measured number inside the range.
By their numbers in this assay, from the lowest: compounds 2 and 4 (each within the scatter of the next); then compounds 1 and 3 (each within the scatter of the next).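

In this assay, 2,6-dimethoxyphenyl on a carbon with a double bond to nitrogen gives a modest improvement over 4-hydroxyphenyl, with a 2.3-fold lower number from compound 3 to compound 4 (0.36 log units; beyond the scatter), and over phenyl, with a 2.0-fold lower number from compound 1 to compound 4 (0.31 log units; beyond the scatter). It also stays level with 2-hydroxyphenyl, with a 1.4-fold higher number from compound 2 to compound 4 (0.15 log units; within the scatter), so among these compounds a hydrogen-bond donor on this ring is not required to get past phenyl. No measurement here accounts for these steps. The compounds shown leave open whether a single methoxy group would suffice, and how an amine or a carboxylic acid on this ring would read.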